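The compounds below may be only part of what the source reports. "The series", "measured", "known", "first", "only" and "open" are said of these compounds alone.

This account follows the series from compound 1 `Cc1ccc(S(=O)(=O)N[C@@H](CC(=O)NC(C)(C)C)C(=O)NCCNC(=O)c2ccccc2)cc1` to its dimethoxy analogue. In an ADME assay on HepG2 cells (Homo sapiens) for cytotoxicity (a higher number here means that more compound is needed for the effect, a lower number that less compound is needed), compound 1 gives > 11000 nM, which is a limit of the assay and not a number, so compound 1 stands only at that boundary, with no closer value to place it. Compound 2 `Cc1ccc(S(=O)(=O)N[C@@H](CC(=O)NC(C)(C)C)C(=O)NCCNC(=O)c2c(O)cccc2F)cc1` carries 2-fluoro-6-hydroxyphenyl in place of phenyl on the carbonyl carbon, and in this assay compound 2 gives > 11000 nM, again a limit. Compound 3 `Cc1ccc(S(=O)(=O)N[C@@H](CC(=O)NC(C)(C)C)C(=O)NCCNC(=O)c2ccccc2F)cc1` carries fluoro in place of hydrogen on an aromatic carbon, and in this assay compound 3 gives > 11000 nM, also a limit. The steps among these three, a step that the two limits leave unreadable from compound 1 to compound 2, a step that the two limits leave unreadable from compound 1 to compound 3 and a step that the two limits leave unreadable from compound 2 to compound 3, cannot be sized because of the limit of > 11000 nM in this assay, at which 3 of the 3 values shown sit.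

The unmeasured compound 4 `COc1cc(OC)cc(C(=O)NCCNC(=O)[C@H](CC(=O)NC(C)(C)C)NS(=O)(=O)c2ccc(C)cc2)c1` differs from compound 1 by 3,5-dimethoxyphenyl in place of phenyl on a carbonyl carbon. The two measured changes on the benzoyl end each left their compound at the limit, so for the step from compound 1 to compound 4 in this assay no step beyond the scatter is expected, and compound 4 is most likely to return a limit as well. Compound 4 is estimated at 15000 nM, within a range from 8000 nM to 40000 nM. That estimate means an expected step that the limit leaves unreadable from compound 1 to compound 4.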

Compound 4, half-maximal effective concentration: > 11000 nM
Compound 4 ended at the assay's limit (the forecaster's own chance of this, stated with the estimate: 85%); the middle value does not contradict the limit.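

In this assay compound 4 gives > 11000 nM as a limit of the assay and not a number. Among the compounds shown here, no step from compound 1, compound 2 or compound 3 to compound 4 can be read, because all four stand at the same boundary: (the limit of > 11000 nM in this assay, at which 4 of the 4 values shown sit). The compounds shown leave open what concentration gives the half-maximal effect for any of them, and whether they differ at all.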